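The source may hold more compounds than are shown below. What is called first, only, known or untested is meant among the compounds shown, and "the series" means these compounds.

Working notes on the series. Two compounds have numbers in a functional assay on the whole organism with Rattus norvegicus as the target, at a dose of 1 mg/kg by the oral route (on this read-out higher numbers stand for a stronger effect at the one dose given and lower numbers for a weaker effect), so far. Compound 1, `COc1cc(C(=O)Nc2nn[nH]n2)nc(-c2ccc(N)cc2)c1`, gives 50% in this assay. Compound 2, `CCCOc1cc(C(=O)Nc2nn[nH]n2)nc(-c2ccccc2)c1`, gives 27% in this assay. Compound 2 therefore stands lowest of the two numbers; its nearest neighbour is compound 1, whose number is higher by a gap that lies beyond the usual scatter. Among the measured compounds shown here, no pair of measured compounds differs in only one place, so no single-point step has been measured yet, and what separates compound 1 from compound 2 involves more than one change at once.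

The next compound to be measured is compound 3, `O=C(Nc1nn[nH]n1)c1cccc(-c2ccccc2)n1`. Relative to compound 2 the change is hydrogen in place of propoxy on an aromatic carbon. There is no measured step of this kind in the series, so the size of the effect in this assay cannot be read off from existing data. The expectation is a small downward step, a number 7 percentage points lower from compound 2 to compound 3 (within the scatter), not clearly beyond the scatter. Compound 3 is thus estimated at 20%, within a range from 5% to 40%.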

Compound 3, a percentage reported as inhibition, in the whole organism at one dose (the size of the read-out at that dose, not a potency): 36%
Estimate against measurement, compound 3: 16 percentage points below, and the stated range covers the measured number.
By their numbers in this assay, from the lowest: compounds 2 and 3 (each within the scatter of the next); then compound 1.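

Among the compounds shown here, this is the first step that changes a single place: in this assay, hydrogen in place of propoxy on the aromatic carbon opposite the ring nitrogen gives a number 9 percentage points higher from compound 2 to compound 3 (within the scatter) and so stays inside the scatter. At the one oral dose given, the whole propoxy chain can therefore be taken away from this carbon without a change that can be told from repeat variation, and the read-out does not depend on that chain being present in any way these two compounds can resolve. Nothing on hand bears on the reason for this result.

Going by these compounds, whether a chain longer than propoxy, such as butoxy, or a carboxylic acid on this same carbon would move the read-out beyond the scatter remains open. Also open, on these data alone, is how much each of the places in which compound 1 at 50% differs from compound 3 contributes to its number, as those places are changed together in that pair.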